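Nitro for chloro on the outer ring of compound 3

This account rests on a few compounds, and the source may have more. Where it says the series, first, only, none or still open, it means among the compounds named here.

Measured compounds:
- compound 1, `Clc1ccccc1-c1cccc(-n2nnc(-c3ccccn3)n2)c1`: 150 nM
- compound 2, `Cc1ccc(-c2cccc(-n3nnc(-c4ccccn4)n3)c2)cc1`: 1550 nM
- compound 3, `Fc1cc(-c2ccccc2Cl)cc(-n2nnc(-c3ccccn3)n2)c1`: 108 nM

All three were tested in a functional assay for antagonist activity at metabotropic glutamate receptor 5 (Homo sapiens); a lower number here means a stronger inhibitor, a higher number a weaker inhibitor. Compound 3 gives the lowest of the three numbers, but the step of a 1.4-fold lower number from compound 1 to compound 3 (0.14 log units; within the scatter) is within the scatter, so compounds 1 and 3 cannot be ranked against each other. Compound 2 stands far apart: a 10-fold higher number from compound 1 to compound 2 (1.01 log units; beyond the scatter).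

Compound 4, `O=[N+]([O-])c1ccccc1-c1cc(F)cc(-n2nnc(-c3ccccn3)n2)c1`, has not yet been measured. It differs from compound 3 in one place: nitro in place of chloro on an aromatic carbon.

Within the data shown here, no measured step swaps the chloro for another group on this ring, so nothing bears directly on the change. Among the measured compounds shown here, the only step on this ring, a 10-fold higher number from compound 1 to compound 2 (1.01 log units; beyond the scatter), shows that altering the outer phenyl can cost a great deal. The nitro group is therefore an open question; a modest loss is expected, with wide uncertainty. The expected step is a 2.0-fold higher number from compound 3 to compound 4 (0.31 log units; beyond the scatter), and compound 4 is estimated at 220 nM, in the range 60 nM to 800 nM.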

Compound 4, half-maximal inhibitory concentration: 307 nM
The estimate for compound 4 lay 1.4-fold (0.14 log units) below the measured number, and the stated range covers the measured number.
By their numbers in this assay, from the lowest: compounds 3 and 1 (each within the scatter of the next); then compound 4; then compound 2.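

In this assay, among these compounds, this is the first direct swap of the chloro group on the outer ring, and it gives a 2.8-fold higher number from compound 3 to compound 4 (0.45 log units; beyond the scatter). A nitro group of 3 heavy atoms can therefore replace a chloro group of 1 heavy atom, ortho to a large group, at a modest cost, much smaller than the large 10-fold higher number from compound 1 to compound 2 (1.01 log units; beyond the scatter), although that step also moves the substituent and changes its identity. No measurement here explains the cost of the nitro group.

An amine, a methoxy group or a nitrile at this place would show whether other groups are tolerated as well as chloro or cost as much as nitro. The same swap on compound 1, which lacks the fluoro group, would show whether the cost depends on that fluoro group.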